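The source may hold more compounds than are shown below. What is called first, only, known or untested is meant among the compounds shown, and "the series" means these compounds.

Of the compounds shown here, three sharing one core have been measured in an ADME assay on RAW264.7 cells (Mus musculus) for cytotoxicity, read by MTT assay, with a stated time of 48 h, tested at 100 uM; a higher number here means more inhibition at the concentration tested (going by the name of the read-out), a lower number less inhibition. Compound 1 `COc1cnc2ccc(=O)n(CCN3CCC(NC(=S)NCc4ccc(Cl)cc4)CC3)c2c1` gives 29.5%. Compound 3 `COc1cnc2ccc(=O)n(CCN3CCC(NC(=O)NCc4ccc(Cl)cc4)CC3)c2c1` gives 40.9%, and the step of a number 11.4 percentage points higher from compound 1 to compound 3 (beyond the scatter) is the only one here that clears the usual scatter. Compound 2 `COc1ccc(CNC(=O)NC2CCN(CCn3c(=O)ccc4ncc(OC)cc43)CC2)cc1` gives 39.5%, the second highest of the three numbers; its nearest neighbour is compound 3, and even its furthest, compound 1, lies within the scatter, so no order among the three can be read from these values.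

Compound 4 `COc1ccc(CNC(=O)NC2CCN(CCn3c(=O)ccc4ncc(F)cc43)CC2)cc1` differs from compound 2 in a single place: fluoro in place of methoxy on an aromatic carbon. Neither measured step bears directly on this change. The step of a number 1.4 percentage points higher from compound 2 to compound 3 (within the scatter) swaps a group on another aromatic carbon, and the step of a number 11.4 percentage points higher from compound 1 to compound 3 (beyond the scatter) alters the group on the amine nitrogen, not the fused core. With no guidance at this position, no step beyond the scatter is expected, and the expected step is a number 1.5 percentage points lower from compound 2 to compound 4 (within the scatter). Compound 4 is therefore estimated at 38%, with a range from 25% to 52%.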

Compound 4, a percentage reported as inhibition, at one concentration (the size of the read-out at that concentration, not a potency): 32.1%
Beside the measured number, compound 4's estimate is 5.9 percentage points above it; measured number inside the range.
By their numbers in this assay, from the lowest: compounds 1, 4, 2 and 3 (each within the scatter of the next, the first and the last beyond it).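

Going by these compounds alone, this is the first view of the position two atoms from the ring nitrogen, in the shared core. In this assay, fluoro in place of methoxy comes with a number 7.4 percentage points lower from compound 2 to compound 4 (within the scatter), so this swap does not move the reading clear of the usual spread of repeats. Losing the methoxy, with its two heavy atoms and one hydrogen-bond acceptor, for a single fluorine with no acceptor therefore leaves no firm mark on this number, and nothing shown here accounts for the size of the step.

Still open, going by these compounds, is whether a different group on this carbon, such as an amine, a nitrile or a longer alkoxy chain, would give a step beyond the scatter. On these data alone, it is also open whether fluoro would behave the same way with chloro on the other aromatic ring.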